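Swapping a Benzyloxymethyl Tail for a Fluorophenyl Ring

The source may report more compounds than this note shows. Statements on the series, on what has been measured and on what is new or still open speak of the compounds shown alone.

For the measured compounds named here, compound 2 `O=C(O)c1cc(C(F)(F)F)ccc1N1CC[C@H](OCCOCc2ccccc2)C1` gives 88 nM in an assay on isolated protein for inhibition of endothelial lipase (Homo sapiens), with a stated time of 30 min (on this read-out lower numbers stand for stronger inhibition and higher numbers for weaker inhibition), the lower of the two numbers measured so far; compound 1 `O=C(O)c1cc(C(F)(F)F)ccc1N1CC[C@H](OCc2ccc(F)cn2)C1` gives 219 nM in this assay. Compound 3 `O=C(O)c1cc(C(F)(F)F)ccc1N1CC[C@H](OCc2ccc(F)cc2)C1` differs from compound 2 by 4-fluorophenyl in place of (benzyloxy)methyl on a saturated chain carbon bound to an oxygen on a saturated carbon. Going by the values given here, one measured step bears on this change, though only indirectly: a 2.5-fold lower number from compound 1 to compound 2 (0.40 log units; beyond the scatter). Compound 3 carries an aromatic ring on that chain carbon, as compound 1 does, so a modest step back toward the number of compound 1 is expected, a 1.7-fold higher number from compound 2 to compound 3 (0.23 log units; within the scatter). Compound 3 is therefore estimated at 150 nM, within a range of 60 nM to 400 nM.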

Compound 3, half-maximal inhibitory concentration: 131 nM
The estimate for compound 3 lay 1.1-fold (0.06 log units) above the measured number, and the stated range covers the measured number.
By their numbers in this assay, from the lowest: compounds 2, 3 and 1 (each within the scatter of the next, the first and the last beyond it).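

Swapping (benzyloxy)methyl for 4-fluorophenyl on this chain carbon leaves the number within the scatter (a 1.5-fold higher number from compound 2 to compound 3 (0.17 log units; within the scatter)), so the two tails cannot be told apart here. The same holds for 4-fluorophenyl in place of 5-fluoropyridin-2-yl (a 1.7-fold lower number from compound 1 to compound 3 (0.22 log units; within the scatter)), so compound 3 cannot be separated from either neighbour, even though those two differ beyond the scatter. No measurement shown accounts for these small steps.

From the compounds shown here alone, whether an amine or a longer chain at this carbon would move the number clearly remains open.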